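A few compounds are considered here, and "the series" means these few. Any claim that something is new, unique, unknown or untested is made for them only; others in the source may bear on it.

Measured compounds:
compound 1 `CCOC(=O)c1nc2ccccc2nc1C#Cc1ccccc1` gives 3300 nM in a functional assay on U-87MG ATCC cells (Homo sapiens) for antiproliferative activity, read by MTT assay, with a stated time of 72 h; on this read-out higher numbers stand for weaker inhibition and lower numbers for stronger inhibition
compound 2 `CCOC(=O)c1nc2ccccc2nc1C#Cc1ccc(C)cc1` gives 3300 nM in this assay
compound 3 `CCOC(=O)c1nc2ccccc2nc1C#Cc1ccccc1OC` gives 11600 nM in this assay

Compound 3 carries the highest of the three numbers. The steps of a 3.5-fold higher number from compound 1 to compound 3 (0.55 log units; beyond the scatter) and a 3.5-fold higher number from compound 2 to compound 3 (0.55 log units; beyond the scatter) both lie beyond the scatter, while no change at the digits printed from compound 1 to compound 2 (within the scatter) shows no change. Compound 4 `CCOC(=O)c1nc2ccccc2nc1C#CC1CC1` is not yet measured; it differs from compound 3 as follows: cyclopropyl in place of 2-methoxyphenyl on a triple-bonded carbon.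

Going by the values given here, no measured step compares a cyclopropyl with an aromatic group on the triple-bonded carbon, so the direction can only be guessed from the two steps that exist. Those steps show that the 2-methoxyphenyl end gives the higher number among the three, whereas the phenyl and 4-methylphenyl ends sit together. Removing the 2-methoxyphenyl is therefore expected to bring the number back toward the range of compound 1 and compound 2, though with wide uncertainty. The expected step is a 2.3-fold lower number from compound 3 to compound 4 (0.37 log units; beyond the scatter). Compound 4 is estimated at 5000 nM, within 1500 nM to 16000 nM.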

Compound 4, half-maximal inhibitory concentration: 6200 nM
Compound 4: the middle estimate sits 1.2-fold (0.09 log units) below what was measured, within the range that was stated.
By their numbers in this assay, from the lowest: compounds 1, 2, 4 and 3 (each within the scatter of the next, the first and the last beyond it).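

In this assay, cyclopropyl on the triple-bonded carbon stays within the scatter of all three aromatic ends: the steps read a 1.9-fold lower number from compound 3 to compound 4 (0.27 log units; within the scatter) and a 1.9-fold higher number from compound 2 to compound 4 (0.27 log units; within the scatter) and a 1.9-fold higher number from compound 1 to compound 4 (0.27 log units; within the scatter) in turn. An aromatic ring at this place is therefore not needed for a number in this range, and going from 8 heavy atoms to 3 brings no change beyond the scatter; compound 4 also cannot be placed with either side of the gap that separates compound 3 from compound 1 and compound 2. No measurement here bears on why the numbers fall as they do.

The compounds shown leave open how an amine or a longer alkyl chain on the triple-bonded carbon would read. Also open, on these data alone, is whether any group at this place can give a number clearly lower than that of compound 1.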